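Two hydroxyphenyl pyridines at the cytotoxicity ceiling

The compounds below may be only part of what the source reports. "The series", "measured", "known", "first", "only" and "open" are said of these compounds alone.

Compound 1, `Oc1ccccc1-c1cc(-c2ccsc2)cc(-c2ccccc2O)n1`, in a functional assay on DU-145 cells (Homo sapiens) for cytotoxicity, read by CCK-8 assay (a lower number here means a stronger inhibitor, a higher number a weaker inhibitor), gives > 50000 nM, a limit of the assay rather than a number.
Compound 2, `Oc1ccc(-c2cc(-c3ccsc3)cc(-c3ccccc3O)n2)cc1`, in this assay gives > 50000 nM, again a limit of the assay.
Compound 3, `Oc1ccccc1-c1cc(-c2ccco2)cc(-c2ccccc2O)n1`, in this assay gives > 50000 nM, also a limit of the assay.

Compound 3 thus stands where every measured compound stands: at the ceiling of this assay, as the limit of > 50000 nM in this assay, at which 3 of the 3 values shown sit, shows, with no numerical value to set it apart from compound 1 or compound 2. The two measured steps are a step that the two limits leave unreadable from compound 1 to compound 2 and a step that the two limits leave unreadable from compound 1 to compound 3; both are unreadable, since a limit on each side gives no size and no direction.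

Compound 4, `Oc1ccc(-c2cc(-c3ccco3)cc(-c3ccccc3O)n2)cc1`, has not yet been measured in this assay. It differs from compound 3 by 4-hydroxyphenyl in place of 2-hydroxyphenyl on an aromatic carbon. The same exchange of a 2-hydroxyphenyl for a 4-hydroxyphenyl was made from compound 1 to compound 2, and there it produced nothing readable, both ends sitting at the limit. No measured step therefore gives a reason to expect compound 4 to leave the ceiling, and the expected step that the limit leaves unreadable from compound 3 to compound 4 is none beyond the scatter. Compound 4 is estimated at 60000 nM, with a range from 20000 nM to 200000 nM, most likely reported again only as a limit in this assay.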

Compound 4, half-maximal inhibitory concentration: > 50000 nM
Compound 4 ended at the assay's limit; the forecaster's own chance of this, stated with the estimate: 85%; the middle value does not contradict the limit.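

Compound 4 ends at the limit of the assay, as compound 2 and compound 3 do, so neither step leading to compound 4 can be read in this assay, and the result stays a limit rather than a number: the limit of > 50000 nM in this assay, at which 4 of the 4 values shown sit.

The compounds shown leave open whether either exchange changes cytotoxicity at all, and how far each compound lies beyond that limit.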